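Series notes: growth-inhibition limits and a bromoalkyl side chain

A few compounds are considered here, and "the series" means these few. Any claim that something is new, unique, unknown or untested is made for them only; others in the source may bear on it.

Compound 1 `CCCCCCCc1cc2c(=O)n(CC#N)cnc2s1` — > 100 ug/mL
Compound 2 `CCCCCCc1cc2c(=O)n(CC3CC3)cnc2s1` — > 100 ug/mL

Compound 1 sits at the ceiling of the assay: in an ADME assay on A549 cells (Homo sapiens) for cytotoxicity, read by MTT assay, with a stated time of 11 days (on this read-out higher numbers stand for weaker inhibition of growth and lower numbers for stronger inhibition of growth), compound 1 gives > 100 ug/mL, which is a limit and not a number. In this assay compound 2 gives > 100 ug/mL, likewise a limit. Within the data shown here, the only evidence so far is the limit of > 100 ug/mL in this assay, at which 2 of the 2 values shown sit. Compound 3 `CCCCCCCc1cc2c(=O)n(CCCBr)cnc2s1` differs from compound 1 by 2-bromoethyl in place of cyano on a saturated chain carbon bound to an aromatic nitrogen. Among the measured compounds shown here, no measured step covers such a change. The expected step is a step that the limit leaves unreadable from compound 1 to compound 3, none beyond the scatter. Compound 3 is expected to give 120 ug/mL in this assay, with a range from 40 ug/mL to 300 ug/mL, most probably reported again only as a limit.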

Compound 3, concentration for 50% growth inhibition: 34.2 ug/mL
Compound 3: the middle estimate sits 3.5-fold (0.55 log units) above what was measured; measured number below the stated range.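

This position is not silent in this assay: 2-bromoethyl in place of cyano on a saturated chain carbon bound to an aromatic nitrogen gives an at least 2.9-fold lower number from compound 1 to compound 3 (0.46 log units; beyond the scatter). The size of this step is only a lower bound, as the value of compound 1 is a limit. Compound 3 is the only compound shown with a value off that limit: the limit of > 100 ug/mL in this assay, at which 2 of the 3 values shown sit.

Cyanomethyl to 3-bromopropyl alters both chain length and end group, so the compounds shown do not separate the contribution of the bromine from that of the chain. From the compounds shown here alone, how a plain propyl chain, a 3-chloropropyl chain or a terminal amine would read at this place remains open.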